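Amino for hydroxy on the fused core of compound 2

A few compounds are considered here, and "the series" means these few. Any claim that something is new, unique, unknown or untested is made for them only; others in the source may bear on it.

Measured compounds:
compound 1 `COC(=O)Nc1cc(N)c2c(c1)NCC(c1ccccc1)=N2`: 24000 nM
compound 2 `CCOC(=O)Nc1cc2nc(O)c(-c3ccccc3)nc2c(N)n1`: 42 nM

In a functional assay on L1210 cells (Mus musculus) (a lower number here means a stronger inhibitor, a higher number a weaker inhibitor), compound 1 gives 24000 nM. In this assay compound 2 gives 42 nM, the lowest of the two numbers; its nearest neighbour is compound 1, whose number is much higher, and the gap between compound 1 and compound 2 lies well beyond the scatter.

Compound 3 `CCOC(=O)Nc1cc2nc(N)c(-c3ccccc3)nc2c(N)n1` has not yet been tested. It differs from compound 2 in one place: amino in place of hydroxy on an aromatic carbon, ortho to a phenyl group. Among the measured compounds shown here, no measured pair shows this exchange, so the size of the step is open. A moderate gain in this assay is expected, though a step within the scatter cannot be excluded. For compound 3 in this assay the estimate is 15 nM, within 3 nM to 150 nM. The expected step is a 2.8-fold lower number from compound 2 to compound 3 (0.45 log units; beyond the scatter).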

Compound 3, half-maximal inhibitory concentration: > 30000 nM
Compound 3 was reported as a limit; the forecaster's own chance of this, stated with the estimate: 5%; middle value at least 2000-fold (3.30 log units) away from the limit.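

At this position, on an aromatic carbon next to the ring nitrogen and ortho to a phenyl group, amino in place of hydroxy gives an at least 710-fold higher number from compound 2 to compound 3 (2.85 log units; beyond the scatter) in this assay. Among the compounds shown here, this is the first pair to isolate the position, and the exchange is large even though the heavy-atom, hydrogen-bond donor and hydrogen-bond acceptor counts stay the same, so hydroxy and amino are not interchangeable here. Compound 3 gives > 30000 nM, which is a limit of the assay and not a number: the limit of > 30000 nM in this assay, at which 1 of the 3 values shown sits.

The compounds shown leave open how a methoxy, thiol or chloro group at this position would read in this assay. Also open, on these data alone, is whether the exchange has a similar size when a pyridyl or cyclohexyl group replaces the phenyl group.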